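Compound 1 to compound 4: an exchanged side group

The source may report more compounds than this note shows. Statements on the series, on what has been measured and on what is new or still open speak of the compounds shown alone.

Compound 1 `O=C(Nc1cccc(Nc2ncc(F)c(Nc3ccc(F)cc3)n2)c1)c1cnccn1` serves as the starting point in a functional assay on KB cells (Homo sapiens) for antiproliferative activity, read by sulforhodamine B assay, with a stated time of 3 days (on this read-out higher numbers stand for weaker inhibition of growth and lower numbers for stronger inhibition of growth), where compound 1 gives 23600 nM. Compound 2 `O=C(Nc1cccc(Nc2ncc(F)c(Nc3ccc(F)cc3)n2)c1)c1cccc([N+](=O)[O-])c1` gives 15100 nM in the same test, and the gap is a 1.6-fold lower number from compound 1 to compound 2 (0.19 log units; within the scatter), so these two numbers cannot be told apart. For compound 3 `CN(C)c1ccc(C(=O)Nc2cccc(Nc3ncc(F)c(Nc4ccc(F)cc4)n3)c2)cc1` the test returns only a limit, > 10000 nM, and not a number. This leaves a step that the limit leaves unreadable from compound 1 to compound 3 and a step that the limit leaves unreadable from compound 2 to compound 3.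

Compound 4 `O=C(Nc1cc(Cl)cc(Cl)c1)c1cccc(Nc2ncc(F)c(Nc3ccc(F)cc3)n2)c1` has not been measured. Its difference from compound 1 is (3,5-dichlorophenyl)carbamoyl in place of ((pyrazin-2-yl)carbonyl)amino on an aromatic carbon. In words, (3,5-dichlorophenyl)carbamoyl takes the place of ((pyrazin-2-yl)carbonyl)amino on an aromatic carbon. Among the measured compounds shown here, no measured step makes this same exchange, as the three measured compounds differ only in the group on a carbonyl carbon. For the measured compounds named here, the one readable guide is compound 2, with a 1.6-fold lower number from compound 1 to compound 2 (0.19 log units; within the scatter), so no shift beyond the scatter is expected in this assay, and the direction stays open. The expected step is a 1.6-fold lower number from compound 1 to compound 4 (0.20 log units; within the scatter). Since the new group has not been tested, the range is kept wide. For compound 4 the estimated value is 15000 nM, with an expected range from 4000 nM to 40000 nM.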

Compound 4, concentration for 50% growth inhibition: 20100 nM
Compound 4: middle estimate off by 1.3-fold (0.13 log units), on the low side; the measured number falls inside the stated range.
By their numbers in this assay, from the lowest: compounds 2, 4 and 1 (each within the scatter of the next).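

In this assay, among the compounds shown here, the earlier compounds differ only in the group on a carbonyl carbon, whereas compound 4 exchanges the whole side group on an aromatic carbon, meta to a large group: the amide link is reversed, so that the carbonyl carbon now sits on that aromatic carbon, and a 3,5-dichlorophenyl ring replaces the pyrazin-2-yl ring. This wider exchange gives a 1.2-fold lower number from compound 1 to compound 4 (0.07 log units; within the scatter) and leaves the two numbers impossible to tell apart. At this position, reversing the link and exchanging the ring together keep the read-out within the scatter, but a single step with two changes cannot show what each change contributes, and their contributions could offset one another.

On these data alone, what stays open is how the number would respond to a plain amine or a carboxylic acid on this aromatic carbon, or to the pyrazin-2-yl ring carried on the reversed link. Compound 3 gives only a limit of > 10000 nM and not a number, so the steps to it cannot be read: the limit of > 10000 nM in this assay, at which 1 of the 4 values shown sits.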